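Spiro-azetidine amides: aryl carbonyl replacing ethylsulfonyl

A few compounds are considered here, and "the series" means these few. Any claim that something is new, unique, unknown or untested is made for them only; others in the source may bear on it.

Compound 2 `CCS(=O)(=O)N1CC2(CN(c3cncc(N4C(=O)c5ccc(Cl)cc5C4(C)C)c3)C2)C1` carries an ethylsulfonyl on the amine nitrogen of the four-membered ring. Within the data shown here, in an assay on cells for inhibition of cytochrome P450 11B2, mitochondrial (Homo sapiens), read by HTRF (on this read-out higher numbers stand for weaker inhibition and lower numbers for stronger inhibition), compound 2 gives 16 nM, the highest number of the two measured so far. Compound 1 `Cn1cc(C(=O)N2CC3(C2)CN(c2cncc(N4C(=O)c5ccc(Cl)cc5C4(C)C)c2)C3)cn1`, which bears a (1-methyl-1H-pyrazol-4-yl)carbonyl at that nitrogen, gives 2 nM in this assay. Among the measured compounds shown here, the one measured step, an 8.0-fold higher number from compound 1 to compound 2 (0.90 log units; beyond the scatter), shows the move from an aryl carbonyl to ethylsulfonyl costing a modest amount.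

Compound 3 `Cc1ccncc1C(=O)N1CC2(C1)CN(c1cncc(N3C(=O)c4ccc(Cl)cc4C3(C)C)c1)C2` reverses that direction: (4-methylpyridin-3-yl)carbonyl in place of ethylsulfonyl on an amine nitrogen in a ring. The change puts an aromatic carbonyl back on the ring nitrogen, as in compound 1, so the step from compound 1 to compound 2 bears on it directly and a lower number of similar size is expected. Compound 3 is therefore estimated at 3 nM in this assay, within 1 nM to 10 nM, an expected step of a 5.3-fold lower number from compound 2 to compound 3 (0.73 log units; beyond the scatter).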

Compound 3, half-maximal inhibitory concentration: 14 nM
Compound 3: middle estimate off by 4.7-fold (0.67 log units), on the low side; the measured number lies above the stated range.
By their numbers in this assay, from the lowest: compound 1; then compounds 3 and 2 (each within the scatter of the next).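

In this assay, an aromatic carbonyl on this amine nitrogen does not by itself carry the low number of compound 1: (4-methylpyridin-3-yl)carbonyl in place of ethylsulfonyl gives a 1.1-fold lower number from compound 2 to compound 3 (0.06 log units; within the scatter) and so does not separate from the sulfonyl. The gap lies instead in the group on the carbonyl carbon, where 4-methylpyridin-3-yl in place of 1-methyl-1H-pyrazol-4-yl gives a 7.0-fold higher number from compound 1 to compound 3 (0.85 log units; beyond the scatter) and leaves compound 1 the lowest of the three. Nothing at hand bears on why these two aromatic groups differ.

From the compounds shown here alone, whether the difference follows the five-membered ring as such or the place of its methyl remains open. Pyridin-3-ylcarbonyl without the methyl, 1-methyl-1H-pyrazol-3-ylcarbonyl and a simple acetyl on the same nitrogen would each help to separate these readings.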